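Solubility Limit Holds Across a Small Series

The source may hold more compounds than are shown below. What is called first, only, known or untested is meant among the compounds shown, and "the series" means these compounds.

Measured compounds in a physicochemical assay for solubility, in the presence of a further agent that is not named here; on this read-out lower numbers stand for lower solubility and higher numbers for higher solubility:
- Compound 1 `Cc1ccc2c(c1)[n+]([O-])c(NCCN(C)C)n[n+]2[O-]` gives > 51000000 nM, which is a limit of the assay and not a number.
- Compound 2 `CC(C)Oc1ccc2c(c1)[n+]([O-])c(NCCN(C)C)n[n+]2[O-]` gives > 51000000 nM, likewise a limit of the assay.

Compound 2 therefore stands at a limit in this assay. Both values shown sit at that same limit (the limit of > 51000000 nM in this assay, at which 2 of the 2 values shown sit). The step that the two limits leave unreadable from compound 1 to compound 2 cannot be read for this reason. Compound 3 `CN(C)CCNc1n[n+]([O-])c2ccc(OCC3CC3)cc2[n+]1[O-]` differs from compound 2 by cyclopropylmethyl in place of isopropyl on an oxygen on an aromatic ring. Going by the values given here, only one measured step bears on this change, and that step is of unreadable size, so it gives no guide to direction. No step beyond the scatter is expected, and the step of a number no higher from compound 2 to compound 3 (the limit leaves the size open) is estimated to be small. Compound 3 is estimated at 51000000 nM, with a range from 20000000 nM to 120000000 nM, and is expected most likely to be reported again only as a limit.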

Compound 3, solubility: > 55000000 nM
Compound 3: only a limit was reported (the forecaster's own chance of this, stated with the estimate: 80%); middle value at least 1.0-fold (0.03 log units) from the limit.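

In this assay compound 1, compound 2 and compound 3 are all reported only as limits, so none of the steps among them can be read. Going by these compounds, how far each true value lies past its limit stays open, as does whether cyclopropylmethyl in place of isopropyl changes the read-out at all.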